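The source may report more compounds than this note shows. Statements on the series, on what has been measured and on what is new or still open speak of the compounds shown alone.

Three compounds on a shared core have numbers in a functional assay on MCF7 cells (Homo sapiens) for antiproliferative activity, read by MTT assay, with a stated time of 48 h; on this read-out lower numbers stand for stronger inhibition and higher numbers for weaker inhibition: compound 1 (`COc1ccc(C(=O)/C=C/c2cc(Br)cc(Br)c2Oc2c([N+](=O)[O-])cc(C(F)(F)F)cc2[N+](=O)[O-])cc1`) gives 3.53 ug/mL, compound 2 (`COc1ccc(C(=O)/C=C/c2cccc(Br)c2Oc2c([N+](=O)[O-])cc(C(F)(F)F)cc2[N+](=O)[O-])cc1`) gives 2.32 ug/mL, and compound 3 (`COc1ccc(C(=O)/C=C/c2cccc(Cl)c2Oc2c([N+](=O)[O-])cc(C(F)(F)F)cc2[N+](=O)[O-])cc1`) gives 1.83 ug/mL. Compound 2 holds the middle number of the three, and both of its measured steps stay within the scatter. With hydrogen in place of bromo on an aromatic carbon, the data show a 1.5-fold lower number from compound 1 to compound 2 (0.18 log units; within the scatter). With chloro in place of bromo on an aromatic carbon, they show a 1.3-fold lower number from compound 2 to compound 3 (0.10 log units; within the scatter).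

Compound 4 (`O=C(/C=C/c1cccc(Br)c1Oc1c([N+](=O)[O-])cc(C(F)(F)F)cc1[N+](=O)[O-])c1ccc(F)cc1`) departs from compound 2 at a different place: fluoro in place of methoxy on an aromatic carbon. In words, this is fluoro in place of methoxy on an aromatic carbon, para to a large group. Among the measured compounds shown here, neither measured step touches that methoxy group, so no measured compound shows directly what this exchange does. The two steps bear on it only as a measure of how little the numbers have moved among these three compounds. The expectation therefore starts from compound 2 at 2.32 ug/mL and assumes no shift beyond the scatter, in either direction. The expected step is a 1.1-fold higher number from compound 2 to compound 4 (0.03 log units; within the scatter). For compound 4 the estimated value is 2.5 ug/mL, with an expected range from 1 ug/mL to 6 ug/mL.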

Compound 4, half-maximal inhibitory concentration: 6.01 ug/mL
Beside the measured number, compound 4's estimate is 2.4-fold (0.38 log units) below it, and the stated range ends below it.
By their numbers in this assay, from the lowest: compounds 3, 2, 1 and 4 (each within the scatter of the next, the first and the last beyond it).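

In this assay, fluoro in place of methoxy gives a 2.6-fold higher number from compound 2 to compound 4 (0.41 log units; beyond the scatter), a modest step and the first among these compounds to lie beyond the scatter. The earlier steps shown here changed only the bromo and chloro groups elsewhere on the shared core and stayed within the scatter, so they gave no sign that a single exchange could move the number this far. This result shows that the number does respond to the group on the 4-methoxyphenyl carbonyl side of the molecule, and that this exchange goes towards weaker inhibition, though nothing available explains why the number moves.

With only one replacement shown at this position, it remains open whether the step reflects the loss of methoxy or the arrival of fluoro, and hydrogen, chloro, ethoxy or a dimethylamino group on the same carbon would help to separate the two. From the compounds shown here alone, it also remains open whether the same exchange would give a step of similar size on the chloro group of compound 3 or the two bromo groups of compound 1.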